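Sulfonylamino in place of imidazolyl on the saturated ring

The compounds below may be only part of what the source reports. "The series", "measured", "known", "first", "only" and "open" are said of these compounds alone.

Measured in an assay on isolated protein for inhibition of eIF-2-alpha kinase GCN2 (Homo sapiens); a lower number here means a stronger inhibitor, a higher number a weaker inhibitor:
compound 1 : `COCCNC(=O)[C@@H]1CC[C@@H](Nc2ncc3c(Br)nn(-c4ccc5ncccc5c4)c3n2)C1`; compound 1 gives 5 nM
compound 2 : `Brc1nn(-c2ccc3ncccc3c2)c2nc(N[C@@H]3CC[C@@H](c4ncc[nH]4)C3)ncc12`; compound 2 gives 21 nM

Among the compounds with values here, compound 2 holds the higher of the two numbers, with compound 1 as its only neighbour, separated by a 4.2-fold higher number from compound 1 to compound 2 (0.62 log units; beyond the scatter). Compound 3 `COCCS(=O)(=O)N[C@@H]1CC[C@@H](Nc2ncc3c(Br)nn(-c4ccc5ncccc5c4)c3n2)C1` differs from compound 2 in this way: ((2-methoxyethyl)sulfonyl)amino in place of 1H-imidazol-2-yl on a saturated ring carbon. Within the data shown here, the single step that bears on it is a 4.2-fold higher number from compound 1 to compound 2 (0.62 log units; beyond the scatter), in which the (2-methoxyethyl)carbamoyl group went with the lower number. Compound 3 restores a 2-methoxyethyl chain bearing one hydrogen-bond donor, so a step back in that direction is expected, a 2.1-fold lower number from compound 2 to compound 3 (0.32 log units; beyond the scatter), though not necessarily the full way. Compound 3 is estimated at 10 nM, within 3 nM to 35 nM.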

Compound 3, half-maximal inhibitory concentration: 55 nM
Compound 3: the middle estimate sits 5.5-fold (0.74 log units) below what was measured; measured number above the stated range.
By their numbers in this assay, from the lowest: compound 1; then compound 2; then compound 3.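

In this assay, the 2-methoxyethyl chain alone does not secure the lower number: with ((2-methoxyethyl)sulfonyl)amino in place of (2-methoxyethyl)carbamoyl, the result is an 11-fold higher number from compound 1 to compound 3 (1.04 log units; beyond the scatter). The sulfonylamino group also falls short of 1H-imidazol-2-yl, with a 2.6-fold higher number from compound 2 to compound 3 (0.42 log units; beyond the scatter), so the order on this saturated ring carbon is carbamoyl, imidazolyl, sulfonylamino. No supporting evidence accounts for this order.

From the compounds shown here alone, whether a simple amine or a carboxylic acid on this carbon would sit nearer compound 1 or compound 3 remains open. So does whether a longer chain on the carbamoyl group would keep the low number.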